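This account rests on a few compounds, and the source may have more. Where it says the series, first, only, none or still open, it means among the compounds named here.

- compound 1 `Fc1ccc(-c2nn3c(-c4ccncc4)nnc3s2)cc1Cl`: 46.6%
- compound 2 `Fc1ccc(OCc2nn3c(-c4ccncc4)nnc3s2)cc1`: 25.6%
- compound 3 `c1ccc2c(C3=Nn4c(nnc4-c4ccncc4)SC3)cccc2c1`: 59.9%

In a functional assay on NCI-H157 cells (Homo sapiens) for antiproliferative activity, read by sulforhodamine B assay, with a stated time of 48 h, tested at 1 uM (on this read-out lower numbers stand for less inhibition of growth and higher numbers for more inhibition of growth at the one concentration tested), compound 2 gives 25.6%, the lowest of these three numbers. Compound 1 gives 46.6% and compound 3 gives 59.9%, and both lie above compound 2 by more than the usual scatter.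

Compound 4 `COc1ccc(OCc2nn3c(-c4ccncc4)nnc3s2)cc1` differs from compound 2 in one place only: methoxy in place of fluoro on an aromatic carbon. This puts methoxy in place of fluoro on an aromatic carbon, para to a large group, turning a 4-fluorophenyl into a 4-methoxyphenyl.

Going by the values given here, no two measured compounds differ in just one place, so the data offer no direct guide to this swap. The three values show only that results in this assay can vary widely across different structures. The expected a number 4.4 percentage points higher from compound 2 to compound 4 (within the scatter) is small and upward, and it may well stay within the scatter. Compound 4 is estimated at 30%, with an expected range from 12% to 50%.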

Compound 4, percent growth inhibition at one concentration: 61.7%
For compound 4 the middle estimate is 31.7 percentage points below the measured one, outside the stated range (above it).
By their numbers in this assay, from the lowest: compound 2; then compound 1; then compounds 3 and 4 (each within the scatter of the next).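

In this assay, going by these compounds alone, the change from 4-fluorophenyl to 4-methoxyphenyl gives a number 36.1 percentage points higher from compound 2 to compound 4 (beyond the scatter) and is the first comparison here in which everything else in the molecule stays the same. It shows that this aromatic carbon, para to a large group, is not a silent position: replacing one small group with another, with no ring added and no net charge introduced, is enough to change the growth inhibition clearly. Nothing shown explains why this swap has so large an effect.

The compounds shown leave open how other groups at this carbon would compare, such as a hydroxyl, an ethoxy or a dimethylamino group. They also leave open whether the same swap would give a similar step on a different scaffold, such as that of compound 1.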